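From Methyl to Dimethylamino on the Shared Core

This account rests on a few compounds, and the source may have more. Where it says the series, first, only, none or still open, it means among the compounds named here.

Compound 1 `CNc1nc2c(-c3ccnc(OC)c3)cnn2cc1OC` gives 74% here
Compound 2 `COc1cc(-c2cnn3cc(OC)c(-c4cc(C)no4)nc23)ccn1` gives 62% here
Compound 3 `COc1cc(-c2cnn3cc(OC)c(C)nc23)ccn1` gives 13% here

These three values come from an ADME assay on microsomes from liver (Rattus norvegicus) for metabolic stability, with a stated time of 60 min, tested at 1 uM (on this read-out higher numbers stand for a more stable compound and lower numbers for a less stable compound), and differ only in one group on the shared core. Compound 3 stands lowest of the three, and both other compounds lie beyond the scatter above it.

The next compound changes exactly that group. Compound 4 `COc1cc(-c2cnn3cc(OC)c(N(C)C)nc23)ccn1` carries dimethylamino in place of methyl on an aromatic carbon, and the change is counted as dimethylamino in place of methyl on an aromatic carbon in full.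

Among the compounds with values here, two measured steps bear on this. The closer one is a number 61 percentage points lower from compound 1 to compound 3 (beyond the scatter) and accompanies methyl in place of methylamino. The other is a number 49 percentage points lower from compound 2 to compound 3 (beyond the scatter) and accompanies methyl in place of 3-methyl-1,2-oxazol-5-yl. Both are large, and in each the methyl compound is the lower one. Within the data shown here, no measured pair shows what dimethylamino does compared with methylamino, so the read from compound 1 is only indirect. Leaving methyl is therefore expected to bring a large rise, though probably not the whole distance. The estimated step is a number 37 percentage points higher from compound 3 to compound 4 (beyond the scatter) in this assay. Compound 4 is expected at 50% with an estimated range from 25% to 75% in this assay once measured.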

Compound 4, percent of the compound remaining: 3%
Compound 4: the middle estimate sits 47 percentage points above what was measured; the whole stated range lies above it.
By their numbers in this assay, from the lowest: compounds 4 and 3 (each within the scatter of the next); then compound 2; then compound 1.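

In this assay, the step from methyl to dimethylamino on this aromatic carbon reads a number 10 percentage points lower from compound 3 to compound 4 (within the scatter), so the two groups cannot be told apart here, and a nitrogen attached at this position does not by itself go with a high number. The new compound shows instead how much turns on a single methyl on that nitrogen: with methyl in place of hydrogen, the read-out is a number 71 percentage points lower from compound 1 to compound 4 (beyond the scatter), a large step from so small a change, and 3-methyl-1,2-oxazol-5-yl also stands well clear of dimethylamino, at a number 59 percentage points lower from compound 2 to compound 4 (beyond the scatter). Nothing measured here explains why the methylamino compound and the dimethylamino compound part so widely.

The compounds shown leave open whether a plain amino group or ethylamino would stay with compound 1 or fall with compound 3 and compound 4, and whether a cyclic amine such as azetidine or morpholine would behave like dimethylamino. They also leave open whether another five-membered aromatic ring, such as a pyrazole, would hold up as 3-methyl-1,2-oxazol-5-yl does.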